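A sulfur substituent exchanged on compound 2

The source may report more compounds than this note shows. Statements on the series, on what has been measured and on what is new or still open speak of the compounds shown alone.

Values in a functional assay on U2OS cells (Homo sapiens) for antiproliferative activity, read by MTT assay, with a stated time of 72 h (a higher number here means a weaker inhibitor, a lower number a stronger inhibitor), so far
Compound 1 `O=C(Cc1nnc(NC(=O)c2ccc(Cl)cc2)s1)N/N=C/c1ccc(O)cc1` gives > 100000 nM (a limit)
Compound 2 `O=C(CSc1nc2ccccc2[nH]1)Nc1ccc2nc(NC(=O)c3ccc(C(F)(F)F)cc3)sc2c1` gives 7110 nM
Compound 3 `O=C(CSc1cccc(O)c1)Nc1ccc2nc(NC(=O)c3ccccc3)sc2c1` gives > 100000 nM (a limit)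

Compound 2 alone has a true number on this scale (7110 nM). Compound 1 and compound 3 give only a limit (the limit of > 100000 nM in this assay, at which 2 of the 3 values shown sit). Compound 4 `Cc1ccc(SCC(=O)Nc2ccc3nc(NC(=O)c4ccc(C(F)(F)F)cc4)sc3c2)c(C)c1` carries 2,4-dimethylphenyl in place of 1H-benzimidazol-2-yl on a sulfur, and the rest of compound 2 stays unchanged. For the measured compounds named here, no measured pair isolates this exchange, so the expectation rests on compound 2 alone. A moderate weakening in this assay is expected, and the estimated change is this (a 2.1-fold higher number from compound 2 to compound 4 (0.32 log units; beyond the scatter)). For compound 4 the estimated value is 15000 nM with 4000 nM as the expected lower end and 80000 nM as the upper end of the range.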

Compound 4, half-maximal inhibitory concentration: 1000 nM
The estimate for compound 4 lay 15-fold (1.18 log units) above the measured number, outside the stated range (below it).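

In this assay, the sulfur substituent tolerates exchange, and the change runs toward a stronger inhibitor: the step is a 7.1-fold lower number from compound 2 to compound 4 (0.85 log units; beyond the scatter). So 1H-benzimidazol-2-yl is not required on this sulfur, and 2,4-dimethylphenyl, with no hydrogen-bond donor or acceptor, gives the lower number. Nothing measured here accounts for this gain.

Whether both methyl groups are needed remains open, as an unsubstituted phenyl is not among the compounds shown. So does the effect of an amine or a carboxylic acid on that ring.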